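A few compounds are considered here, and "the series" means these few. Any claim that something is new, unique, unknown or untested is made for them only; others in the source may bear on it.

Measured so far:
compound 1 `CC(O)(C(=O)Nc1ccc(S(=O)(=O)c2ccccc2)c(F)c1)C(F)(F)F` — 1800 nM
compound 2 `COc1ccc(S(=O)(=O)c2ccc(NC(=O)C(C)(O)C(F)(F)F)cc2)cc1` — > 30000 nM

The study concerns a functional assay (Cavia porcellus) with sulfonylurea receptors; K-ATP channels (Homo sapiens) as the target; a lower number here means a stronger inhibitor, a higher number a weaker inhibitor. In this assay compound 1 gives 1800 nM. Compound 2 is reported only as a limit of the assay, > 30000 nM, and not as a number. Compound 1 therefore holds the only number shown; the one other value is a limit, as described by the limit of > 30000 nM in this assay, at which 1 of the 2 values shown sits.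

The step taken from compound 1 leads to compound 3 `CC(O)(C(=O)Nc1ccc(S(=O)(=O)c2ccccc2)c([N+](=O)[O-])c1)C(F)(F)F`. The change is nitro in place of fluoro on an aromatic carbon, in words, nitro in place of fluoro on an aromatic carbon. Going by the values given here, no measured pair with the same change is available, so the size of the step cannot be read from the data. In the absence of such evidence, the step from compound 1 to compound 3 is expected to be small, of about a 1.4-fold higher number from compound 1 to compound 3 (0.14 log units; within the scatter), which would lie within the usual scatter. Compound 3 is accordingly estimated at 2500 nM, with a plausible range from 600 nM to 10000 nM.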

Compound 3, half-maximal inhibitory concentration: > 30000 nM
Compound 3: no number, only a limit; the forecaster's own chance of this, stated with the estimate: 10%; middle value at least 12-fold (1.07 log units) from the limit.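

At this position, ortho to a group of 9 heavy atoms and meta to a large group, nitro in place of fluoro on an aromatic carbon gives an at least 16-fold higher number from compound 1 to compound 3 (1.22 log units; beyond the scatter) in this assay, so the position is not indifferent to the group it carries. Compound 3 is reported only as a limit of the assay, > 30000 nM, and not as a number. The step therefore gives a bound, and its full size cannot be read from this pair: the limit of > 30000 nM in this assay, at which 2 of the 3 values shown sit.

The compounds shown leave open whether a nitrile, an amine or a methyl at this position would keep the value of compound 1 or would also reach the limit. Going by these compounds alone, compound 2 differs from compound 1 and from compound 3 in more than one place, so no step involving it can be read.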